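From compound 2 to compound 3: one chain exchanged

The source may hold more compounds than are shown below. What is called first, only, known or untested is meant among the compounds shown, and "the series" means these compounds.

Compound 1 `COC[C@H](C(C)C)C(c1ccc(O)c(OC)c1)c1ccc(O)c(OC)c1`: 76000 nM
Compound 2 `COc1cc(C(c2ccc(O)c(OC)c2)[C@@H](C)[C@H](C)CF)ccc1O`: 37000 nM

In a functional assay on HeLa cells (Homo sapiens) for cytotoxicity, read by WST assay, with a stated time of 48 h (a higher number here means a weaker inhibitor, a lower number a stronger inhibitor), compound 2 holds the lower of the two numbers, at 37000 nM. Compound 3 `COc1cc(C(c2ccc(O)c(OC)c2)[C@H](CC(C)C)C(C)C)ccc1O` is not yet measured. It carries 1-isopropyl-3-methylbutyl in place of the 2-(fluoromethyl)-1-methylpropyl of compound 2, on a saturated chain carbon bound to two aromatic carbons (1-isopropyl-3-methylbutyl in place of 2-(fluoromethyl)-1-methylpropyl on a saturated chain carbon bound to two aromatic carbons). Among the measured compounds shown here, the only measured step at this place is a 2.1-fold lower number from compound 1 to compound 2 (0.31 log units; beyond the scatter). That step is modest and involves different groups, so it suggests a size but no firm direction. A small step is expected, tentatively toward a lower number: a 1.3-fold lower number from compound 2 to compound 3 (0.12 log units; within the scatter). For compound 3 the expected value is 28000 nM, with an estimated range of 11000 nM to 70000 nM.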

Compound 3, half-maximal inhibitory concentration: 8200 nM
Compound 3: middle estimate off by 3.4-fold (0.53 log units), on the high side; the whole stated range lies above it.
By their numbers in this assay, from the lowest: compound 3; then compound 2; then compound 1.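

In this assay, among the compounds shown here, the 1-isopropyl-3-methylbutyl chain brings a 4.5-fold lower number from compound 2 to compound 3 (0.65 log units; beyond the scatter) and a 9.3-fold lower number from compound 1 to compound 3 (0.97 log units; beyond the scatter) as the lowest number so far. This place on a saturated chain carbon bound to two aromatic carbons can therefore shift the number well beyond the scatter, and an all-carbon chain without fluorine or methoxy is enough to do so. Nothing available explains why this chain gives the lower number. Still open, as far as these compounds go, is whether a longer chain would lower the number further, and how a chain ending in an amine or a carboxylic acid would behave.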